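The compounds below may be only part of what the source reports. "The series", "measured", "known", "first", "only" and "open" are said of these compounds alone.

Measured in an ADME assay on ECV-304 cells (Homo sapiens) for cytotoxicity, read by MTT assay, with a stated time of 72 h; a lower number here means a stronger inhibitor, a higher number a weaker inhibitor:
compound 1 `COc1ccc(OC)c(C2=C(c3cc(OC)c(OC)c(OC)c3)C(=O)CC2O[SiH2]C(C)(C)C)c1`: 6.5 ug/mL
compound 2 `COC(=O)c1cc(C2=C(c3cc(OC)c(OC)c(OC)c3)C(=O)CC2O[SiH2]C(C)(C)C)ccc1OC`: > 100 ug/mL

Compound 2 stands at > 100 ug/mL, which is a limit of the assay and not a number. Compound 3 `COc1ccc(C2=C(c3cc(OC)c(OC)c(OC)c3)C(=O)CC2O[SiH2]C(C)(C)C)cc1OC` differs from it by methoxy in place of methoxycarbonyl on an aromatic carbon, turning 4-methoxy-3-(methoxycarbonyl)phenyl into 3,4-dimethoxyphenyl. For the measured compounds named here, one measured step bears on this: an at least 15-fold higher number from compound 1 to compound 2 (1.18 log units; beyond the scatter), where 4-methoxy-3-(methoxycarbonyl)phenyl replaced 2,5-dimethoxyphenyl. Compound 3 loses the methoxycarbonyl group introduced in that step, but its 3,4-dimethoxyphenyl is not the 2,5-dimethoxyphenyl of compound 1. A large move to a lower number is therefore expected in this assay, toward compound 1 at 6.5 ug/mL but not all the way. The expected change is an at least 5.0-fold lower number from compound 2 to compound 3 (0.69 log units; beyond the scatter). For compound 3 the estimate is 20 ug/mL, with an expected range of 4 ug/mL to 100 ug/mL.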

Compound 3, half-maximal inhibitory concentration: > 100 ug/mL
Compound 3 was reported as a limit; the forecaster's own chance of this, stated with the estimate: 20%; middle value at least 5.0-fold (0.69 log units) away from the limit.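

In this assay compound 3 gives > 100 ug/mL, which is a limit of the assay and not a number. Loss of the methoxycarbonyl group therefore does not restore the value of compound 1: the change to 3,4-dimethoxyphenyl alone gives an at least 15-fold higher number from compound 1 to compound 3 (1.18 log units; beyond the scatter), so in this pair a large step occurs with methoxy groups only, and methoxycarbonyl is not required for it. The step between compound 2 and compound 3 cannot be read, because both values sit at the same limit: the limit of > 100 ug/mL in this assay, at which 2 of the 3 values shown sit.

On these data alone, how far compound 2 and compound 3 differ from each other remains open. Also open, as far as these compounds go, is whether a phenyl ring carrying an amine or a carboxylic acid in place of the 2,5-dimethoxyphenyl of compound 1 would stay near compound 1 at 6.5 ug/mL.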